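Notes on the secondary amine series: furanylmethyl to benzyl swap

This account rests on a few compounds, and the source may have more. Where it says the series, first, only, none or still open, it means among the compounds named here.

Compound 1 `Cc1cc(C)cc(Cc2ccc3c(NCCCNCc4ccco4)ccnc3c2)c1` stands highest of the three numbers in a physicochemical assay for acid dissociation, where compound 1 gives 9.47; compound 2 `c1ccc(Oc2ccc3c(NCCCNCc4ccco4)ccnc3c2)cc1` gives 9.28 and compound 3 `Clc1ccc(Oc2ccc3c(NCCCNCc4ccco4)ccnc3c2)cc1` gives 9.28, with a number 0.19 log units lower from compound 1 to compound 2 (within the scatter), a number 0.19 log units lower from compound 1 to compound 3 (within the scatter) and no change at the digits printed from compound 2 to compound 3 (within the scatter). Compound 4 `COc1ccc(F)cc1CNCCCNc1ccnc2cc(Cc3cc(C)cc(C)c3)ccc12` differs from compound 1 in 5-fluoro-2-methoxyphenyl in place of furan-2-yl on a saturated chain carbon bound to an amine nitrogen. Among the measured compounds shown here, none of the measured steps touches that position; all three alter only the group on the aromatic carbon of the shared core, and none moved the read-out beyond the scatter. For the measured compounds named here, no measured step therefore bears directly on this change, and no step beyond the scatter is expected in this assay, so the expected step is a number 0.03 log units higher from compound 1 to compound 4 (within the scatter). Compound 4 is estimated at 9.5, between 9 and 10.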

Compound 4, acid dissociation constant: 9.47
For compound 4 the middle estimate is 0.03 log units above the measured one; low and high end bracket the measured number.
By their numbers in this assay, from the lowest: compounds 2, 3, 1 and 4 (each within the scatter of the next).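

In this assay, the only step shown at this position, 5-fluoro-2-methoxyphenyl in place of furan-2-yl on a saturated chain carbon bound to an amine nitrogen, gives no change at the digits printed from compound 1 to compound 4 (within the scatter). The earlier steps shown here all altered the group on an aromatic carbon of the shared core, whereas this one shows that a six-membered aromatic ring of carbon only can replace the five-membered ring here without a step beyond the scatter. No evidence on the reason for this result is available.

Open, on these data alone, is whether a carboxylic acid or an amine in place of 5-fluoro-2-methoxyphenyl would leave the read-out within the scatter. Also open, as far as these compounds go, is whether the same swap gives a similar step from compound 2 or compound 3.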